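A few compounds are considered here, and "the series" means these few. Any claim that something is new, unique, unknown or untested is made for them only; others in the source may bear on it.

Values in a functional assay on blood (Homo sapiens), with a stated time of 60 min, in the presence of a further agent that is not named here; on this read-out higher numbers stand for an effect only at larger amounts of compound and lower numbers for an effect already at smaller amounts:
- Compound 1 `CON(C)C(=O)C1(S(=O)(=O)c2ccc(Oc3ccc(OC(F)(F)F)cc3)cc2)CCC2(CCNCC2)C1`: 3700 nM
- Compound 2 `O=S(=O)(c1ccc(Oc2ccc(OC(F)(F)F)cc2)cc1)C1(CO)CCC2(CCNCC2)C1`: > 15000 nM
- Compound 3 `O=C(Nc1ccccn1)C1(S(=O)(=O)c2ccc(Oc3ccc(OC(F)(F)F)cc3)cc2)CCC2(CCNCC2)C1`: not yet measured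

Compound 2 gives only a limit of the assay, > 15000 nM, and no number. The change to compound 3 is (pyridin-2-yl)carbamoyl in place of hydroxymethyl on a saturated ring carbon, in words (pyridin-2-yl)carbamoyl in place of hydroxymethyl on a saturated ring carbon. Going by the values given here, one measured step bears on it: an at least 4.0-fold higher number from compound 1 to compound 2 (0.60 log units; beyond the scatter), with hydroxymethyl in place of methoxy(methyl)carbamoyl on a saturated ring carbon. Compound 3 regains a carbamoyl group, as carried by compound 1 at 3700 nM, so a lower number in this assay is expected, of at least modest size, on the evidence of an at least 4.0-fold higher number from compound 1 to compound 2 (0.60 log units; beyond the scatter) read in reverse. This rests on a single step ending at a limit, so the size stays uncertain. The expected change is an at least 4.2-fold lower number from compound 2 to compound 3 (0.63 log units; beyond the scatter). Compound 3 is estimated at 3500 nM, with an expected range of 900 nM to 15000 nM.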

Compound 3, half-maximal effective concentration: > 15000 nM
Compound 3: a limit, no number; the forecaster's own chance of this, stated with the estimate: 25%; middle value at least 4.2-fold (0.63 log units) away from the limit.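

In this assay, a carbonyl group on this saturated ring carbon does not by itself keep the number low: with (pyridin-2-yl)amino in place of methoxy(methyl)amino on the carbonyl carbon, the series shows an at least 4.0-fold higher number from compound 1 to compound 3 (0.60 log units; beyond the scatter). The group on the carbonyl carbon therefore matters at this position, which compound 2, with hydroxymethyl and no carbonyl, could not show. The step from compound 2 to compound 3 cannot be read, so hydroxymethyl and (pyridin-2-yl)carbamoyl cannot be ranked here: the limit of > 15000 nM in this assay, at which 2 of the 3 values shown sit.

Still open, as far as these compounds go, is whether the higher number for compound 3 goes with the pyridine ring or with the amide hydrogen, as compound 1 has neither. A methylamino or a phenylamino group on the same carbonyl carbon would help separate the two.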